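A few compounds are considered here, and "the series" means these few. Any claim that something is new, unique, unknown or untested is made for them only; others in the source may bear on it.

Compound 2 `O=C(Nc1ccc(C(F)(F)F)cc1)c1ccc(OC(F)(F)F)cc1` belongs to a small set of amides that share one core and differ only in the group on the far ring. In a functional assay on HEK293 cells for antagonist activity at transient receptor potential cation channel subfamily V member 1 (Homo sapiens), read by calcium flux (a higher number here means a weaker inhibitor, a lower number a stronger inhibitor), compound 2 gives 220 nM. Of the three numbers measured, this is the highest, but only by margins that fall within the usual scatter. Compound 1 `CC(C)(C)c1ccc(NC(=O)c2ccc(OC(F)(F)F)cc2)cc1` gives 120 nM, and compound 3 `O=C(Nc1ccc2c(c1)CCC2)c1ccc(OC(F)(F)F)cc1` gives 210 nM. Going by the values given here, the one step that has been measured between neighbours is a 1.8-fold higher number from compound 1 to compound 2 (0.26 log units; within the scatter), so swapping one group for another at this position has so far moved the number very little.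

Compound 4 `O=C(Nc1ccc(-c2ccccc2)cc1)c1ccc(OC(F)(F)F)cc1` carries the next change at the same place: phenyl in place of trifluoromethyl on an aromatic carbon. Because the step of a 1.8-fold higher number from compound 1 to compound 2 (0.26 log units; within the scatter) stayed within the scatter, and because compound 3 with its fused ring gives 210 nM, close to compound 2, the expected step of a 1.2-fold lower number from compound 2 to compound 4 (0.09 log units; within the scatter) is small and in no firm direction. Compound 4 is therefore estimated at 180 nM, with a range from 60 nM to 600 nM.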

Compound 4, half-maximal inhibitory concentration: > 10000 nM
Compound 4 ended at the assay's limit; the forecaster's own chance of this, stated with the estimate: 5%; middle value at least 55-fold (1.74 log units) away from the limit.
By their numbers in this assay, from the lowest: compounds 1, 3 and 2 (each within the scatter of the next). At a limit, above all of these: compound 4.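

Phenyl at this position brings an at least 45-fold higher number from compound 2 to compound 4 (1.65 log units; beyond the scatter) and an at least 83-fold higher number from compound 1 to compound 4 (1.92 log units; beyond the scatter). The earlier swap between tert-butyl and trifluoromethyl suggested that this place on the far ring accepts different groups with little effect, but this change shows that it does not accept every group, and that one replacement here can nearly abolish measurable inhibition. Both steps give only a lower bound on the true gap, because compound 4 sits at the edge of what the assay can read: the limit of > 10000 nM in this assay, at which 1 of the 4 values shown sits.

On these data alone, what remains open is whether any aromatic ring at this position has the same effect or only phenyl does. A pyridine ring, a cyclohexyl group or an amine at the same place would help separate these possibilities.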